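From 4-nitrophenyl to thiophen-3-yl on a shared core

The source may report more compounds than this note shows. Statements on the series, on what has been measured and on what is new or still open speak of the compounds shown alone.

- Compound 1 `COc1ccc(C(=O)/C=C/c2ccc(Br)cc2)c2c1C=CC(C)(C)O2`: > 10000 nM (a limit)
- Compound 2 `COc1ccc(C(=O)/C=C/c2ccc(-c3ccccc3)cc2)c2c1C=CC(C)(C)O2`: > 10000 nM (a limit)
- Compound 3 `COc1ccc(C(=O)/C=C/c2ccc([N+](=O)[O-])cc2)c2c1C=CC(C)(C)O2`: 7770 nM

Within the data shown here, in a functional assay on K562 cells (Homo sapiens) for antiproliferative activity, read by MTT assay, with a stated time of 24 h (on this read-out higher numbers stand for weaker inhibition and lower numbers for stronger inhibition), compound 3 gives 7770 nM, the only actual number among the three. Compound 1 gives > 10000 nM, which is a limit. Compound 2 gives > 10000 nM, which is also a limit. What frames compound 3 is therefore (the limit of > 10000 nM in this assay, at which 2 of the 3 values shown sit).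

Compound 4 `COc1ccc(C(=O)/C=C/c2ccsc2)c2c1C=CC(C)(C)O2` is still unmeasured. Its change is thiophen-3-yl in place of 4-nitrophenyl on a double-bonded chain carbon bound to a double-bonded chain carbon, thiophen-3-yl in place of 4-nitrophenyl. Among the measured compounds shown here, two measured steps bear on it, as both arrive at the nitro group: an at least 1.2-fold lower number from compound 1 to compound 3 (0.10 log units; that floor lies within the scatter) and an at least 1.2-fold lower number from compound 2 to compound 3 (0.10 log units; that floor lies within the scatter). Both are small floors that stay within the scatter, and a step that the two limits leave unreadable from compound 1 to compound 2 adds no size. With the 4-nitrophenyl group gone, compound 4 is expected to sit nearer compound 1 and compound 2, but only weakly so. The expected move is toward weaker inhibition, a 1.5-fold higher number from compound 3 to compound 4 (0.19 log units; within the scatter), and it is not expected to clear the scatter. In this assay the estimate for compound 4 is 12000 nM, expected within 6000 nM to 30000 nM.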

Compound 4, half-maximal inhibitory concentration: > 10000 nM
Compound 4: only a limit was reported (the forecaster's own chance of this, stated with the estimate: 55%); the middle value does not contradict the limit.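

Among these compounds, replacing 4-nitrophenyl with thiophen-3-yl on a double-bonded chain carbon bound to a double-bonded chain carbon, the first change here of the whole ring, gives an at least 1.2-fold higher number from compound 3 to compound 4 (0.10 log units; that floor lies within the scatter) in this assay, a floor that by itself shows no real separation. Compound 4 gives > 10000 nM, which is a limit. The step from compound 1 to compound 4 cannot be read, and compound 3, with its nitro group, remains the only compound with an actual number, while a five-membered aromatic ring now joins the bromo and phenyl compounds at the same limit: the limit of > 10000 nM in this assay, at which 3 of the 4 values shown sit.

Going by these compounds, how far compound 1, compound 2 and compound 4 lie beyond that limit remains open. So does whether an amine or a carboxylic acid in place of the nitro group on the shared core would give a readable number.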